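Trimming the Benzofuran: From Compound 3 to Compound 4

This account rests on a few compounds, and the source may have more. Where it says the series, first, only, none or still open, it means among the compounds named here.

All three measured compounds share one core bearing a sugar and differ only in the group on an aromatic carbon of that core. Compound 1 `COc1ncnc2c1c(-c1ccccc1)cn2[C@@H]1O[C@H](CO)[C@@H](O)[C@H]1O` carries a phenyl group; in an ADME assay on MRC5 cells (Homo sapiens), read by MTT assay, with a stated time of 72 h (a lower number here means a stronger inhibitor, a higher number a weaker inhibitor), compound 1 sits at the limit of > 100000 nM. Compound 2 `COc1ncnc2c1c(I)cn2[C@@H]1O[C@H](CO)[C@@H](O)[C@H]1O` carries iodo, and in this assay compound 2 gives 63000 nM. Compound 3 `COc1ncnc2c1c(-c1cc3ccccc3o1)cn2[C@@H]1O[C@H](CO)[C@@H](O)[C@H]1O` carries a 1-benzofuran-2-yl group, and in this assay compound 3 gives 65600 nM. Compound 3 stands at the top of the two numbers, though the gap a 1.0-fold higher number from compound 2 to compound 3 (0.02 log units; within the scatter) lies within the scatter, so the two are not distinguished. Because compound 1 sits at the limit (the limit of > 100000 nM in this assay, at which 1 of the 3 values shown sits), the steps of an at least 1.5-fold lower number from compound 1 to compound 2 (0.20 log units; that floor lies within the scatter) and an at least 1.5-fold lower number from compound 1 to compound 3 (0.18 log units; that floor lies within the scatter) are only floors, and both lie within the scatter.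

Compound 4 `COc1ncnc2c1c(-c1ccco1)cn2[C@@H]1O[C@H](CO)[C@@H](O)[C@H]1O` differs from compound 3 in one place: furan-2-yl in place of 1-benzofuran-2-yl on an aromatic carbon. Going by the values given here, no measured step removes the six-membered aromatic ring of carbon only from a 1-benzofuran-2-yl group, so none bears directly on this change; what is known is that exchanging iodo, phenyl and 1-benzofuran-2-yl at this carbon moved nothing beyond the scatter. The number for compound 4 is therefore expected to stay close to that of compound 3, a step of a 1.0-fold lower number from compound 3 to compound 4 (0.00 log units; within the scatter) with no clear direction. The estimate for compound 4 in this assay is 65000 nM, with a range from 25000 nM to 160000 nM.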

Compound 4, half-maximal inhibitory concentration: 1700 nM
The estimate for compound 4 lay 38-fold (1.58 log units) above the measured number; the whole stated range lies above it.
By their numbers in this assay, from the lowest: compound 4; then compounds 2 and 3 (each within the scatter of the next). At a limit, above all of these: compound 1.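

At this aromatic carbon the group matters after all. In this assay, furan-2-yl gives a 39-fold lower number from compound 3 to compound 4 (1.59 log units; beyond the scatter) and a 37-fold lower number from compound 2 to compound 4 (1.57 log units; beyond the scatter), both beyond the scatter, whereas the exchanges among iodo, phenyl and 1-benzofuran-2-yl moved nothing beyond it, and the first of these two steps only removes the six-membered aromatic ring of carbon only from the 1-benzofuran-2-yl group. Simply shrinking the group does not describe the result, since compound 2 carries no ring at this carbon and still stays within the scatter of compound 3, far from compound 4. Compound 1 sits at a limit of the assay, so an at least 58-fold lower number from compound 1 to compound 4 (1.76 log units; beyond the scatter) is only a floor: the limit of > 100000 nM in this assay, at which 1 of the 4 values shown sits.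

Nothing shown gives a measured reason why furan-2-yl stands apart from the other groups at this carbon. As far as these compounds go, it also stays open whether the low number belongs to furan-2-yl alone or would carry over to a thiophen-2-yl group, with sulfur in place of the ring oxygen, to a furan-3-yl group, or to a non-aromatic group such as an amine or a short alkyl chain.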